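The source may hold more compounds than are shown below. What is called first, only, known or untested is meant among the compounds shown, and "the series" means these compounds.

Compound 1, `CCCCN(CCCC)CCCOc1ccc(S(=O)(=O)c2c(C(C)C)cn3ccccc23)cc1`, gives 21.6 nM in a functional assay (aorta) with Rattus norvegicus as the target; on this read-out lower numbers stand for stronger inhibition and higher numbers for weaker inhibition. Compound 2, `CCCCN(CCCC)CCCOc1ccc(S(=O)(=O)c2c(C(C)(C)C)cn3ccccc23)cc1`, gives 51.9 nM in this assay, and the step of a 2.4-fold higher number from compound 1 to compound 2 (0.38 log units; beyond the scatter) is modest. Compound 3, `CCCCN(CCCC)CCCOc1ccc(S(=O)(=O)c2c(C3CCCCC3)cn3ccccc23)cc1`, gives 4070 nM in this assay; here the steps of a 190-fold higher number from compound 1 to compound 3 (2.28 log units; beyond the scatter) and a 78-fold higher number from compound 2 to compound 3 (1.89 log units; beyond the scatter) are large. Compound 3 therefore stands highest of the three numbers, with compound 2 nearest and compound 1 furthest.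

Compound 4, `CCCCN(CCCC)CCCOc1ccc(S(=O)(=O)c2c(-c3ccccc3)cn3ccccc23)cc1`, differs from compound 3 by phenyl in place of cyclohexyl on an aromatic carbon. Among the measured compounds shown here, no measured step changes a cyclohexyl into a phenyl, so none bears directly on this change. The measured steps only show that the group on this aromatic carbon matters greatly in this assay, with the six-membered cyclohexyl of compound 3 giving a far higher number than the isopropyl of compound 1 or the tert-butyl of compound 2. Phenyl keeps the same six heavy atoms and a six-membered ring, so compound 3 offers the closest guide, though the uncertainty is wide. Compound 4 is therefore expected to stay near the high end, with a step of a 1.6-fold lower number from compound 3 to compound 4 (0.21 log units; within the scatter) that need not exceed the scatter. The estimate for compound 4 in this assay is 2500 nM, within a range from 400 nM to 12000 nM.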

Compound 4, half-maximal inhibitory concentration: 1620 nM
Estimate against measurement, compound 4: 1.5-fold (0.19 log units) above; low and high end bracket the measured number.
By their numbers in this assay, from the lowest: compound 1; then compound 2; then compound 4; then compound 3.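

In this assay the exchange of cyclohexyl for phenyl on this aromatic carbon gives a 2.5-fold lower number from compound 3 to compound 4 (0.40 log units; beyond the scatter) and so moves the number by a modest amount, showing that two groups with the same count of heavy atoms can still be told apart here when one six-membered ring is aromatic and the other is not. The aromatic ring does not bring the number back to the level of the small branched groups, since phenyl in place of tert-butyl gives a 31-fold higher number from compound 2 to compound 4 (1.49 log units; beyond the scatter) and phenyl in place of isopropyl gives a 75-fold higher number from compound 1 to compound 4 (1.88 log units; beyond the scatter) as large steps. Among these four compounds, then, both six-membered rings stand well above isopropyl and tert-butyl, with no compound going against that split, and nothing available explains these differences.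

The compounds shown leave open where a cyclopropyl or cyclopentyl ring would fall between the small branched groups and the six-membered rings. They also leave open whether a pyridyl ring or a phenyl carrying a methoxy group would follow phenyl, and how an ethyl group or plain hydrogen on this carbon would compare with isopropyl.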